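The source may hold more compounds than are shown below. What is called first, only, known or untested is meant among the compounds shown, and "the series" means these compounds.

Compound 1 (`CC1(C)C=C(c2cc(-c3ccc(F)cc3Cl)c3ccc(=O)n(-c4c(Cl)cccc4Cl)c3c2)CC(C)(C)N1`) 30.1 mL/min/kg
Compound 2 (`CC(C)(C)N1CCC(c2cc(-c3ccc(F)cc3Cl)c3ccc(=O)n(-c4c(Cl)cccc4Cl)c3c2)CC1`) 14 mL/min/kg

These two compounds have been measured in an in vivo ADME assay on the whole organism (plasma) for pharmacokinetics, with Rattus norvegicus as the target; on this read-out lower numbers stand for slow clearance and higher numbers for fast clearance. Among the measured compounds shown here, compound 2 holds the lower number of the pair (14 mL/min/kg), and its only neighbour on the scale is compound 1 (30.1 mL/min/kg).

Compound 3 (`CC(C)(C)N1CCC(c2cc(-c3ccc(F)cc3F)c3ccc(=O)n(-c4c(Cl)cccc4Cl)c3c2)CC1`) has not yet been measured. It carries fluoro in place of chloro on an aromatic carbon, so 2-chloro-4-fluorophenyl becomes 2,4-difluorophenyl.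

For the measured compounds named here, only one measured step exists (a 2.2-fold lower number from compound 1 to compound 2 (0.33 log units; beyond the scatter)). It is modest, though beyond the scatter, and it exchanges a different group, while the chloro stays the same in both compounds. It therefore shows how far one change has moved this assay here, but it gives neither the size nor the direction of this exchange. Going by the values given here, no measured pair tests chloro against fluoro, so no shift beyond the scatter is expected. The expected change is slight (a 1.1-fold higher number from compound 2 to compound 3 (0.03 log units; within the scatter)) and its direction is uncertain. For compound 3 the estimate is 15 mL/min/kg (expected range 8 mL/min/kg to 28 mL/min/kg).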

Compound 3, clearance: 11.9 mL/min/kg
Beside the measured number, compound 3's estimate is 1.3-fold (0.10 log units) above it, within the range that was stated.
By their numbers in this assay, from the lowest: compounds 3 and 2 (each within the scatter of the next); then compound 1.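

In this assay, fluoro in place of chloro on this aromatic carbon gives a 1.2-fold lower number from compound 2 to compound 3 (0.07 log units; within the scatter), so 2-chloro-4-fluorophenyl and 2,4-difluorophenyl cannot be told apart on this read-out when the rest of the molecule is that of compound 2. Among the compounds shown here, the only earlier step concerned a different group on the shared core, which makes this the first direct reading of the halogen at this position, and it shows that chloro can give way to fluoro here with compound 3 staying level with compound 2. No supporting measurement is available to explain this result.

Chloro and fluoro are the only groups compared at this position, so it remains open whether hydrogen, a methyl group or a methoxy group on the same carbon would also leave clearance within the scatter. For the compounds shown here, it is also open whether the same exchange would read alike if the group carried by compound 1 replaced the one shared by compound 2 and compound 3, since only one such halogen pair is available.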